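Lengthening the Amide Substituent Beyond Butyl and Hexyl

This account rests on a few compounds, and the source may have more. Where it says the series, first, only, none or still open, it means among the compounds named here.

Compound 1 `NC(=O)[C@H]1OC(n2cnc3c(N)ncnc32)[C@H](O)[C@@H]1O` gives 64 nM in an assay on cell membranes for binding affinity to 2-oxoglutarate receptor 1 (Rattus norvegicus), read by radioligand binding; on this read-out lower numbers stand for stronger inhibition and higher numbers for weaker inhibition.
Compound 2 `CCCCNC(=O)[C@H]1OC(n2cnc3c(N)ncnc32)[C@H](O)[C@@H]1O` gives 17 nM in this assay.
Compound 3 `CCCCCCNC(=O)[C@H]1OC(n2cnc3c(N)ncnc32)[C@H](O)[C@@H]1O` gives 19 nM in this assay.

Compound 1, which carries a bare amide hydrogen, has the highest number of the three, so it stands as the weakest binder among them. Putting a chain on that amide nitrogen lowered the number in both measured cases: a 3.8-fold lower number from compound 1 to compound 2 (0.58 log units; beyond the scatter) and a 3.4-fold lower number from compound 1 to compound 3 (0.53 log units; beyond the scatter). Going from the shorter to the longer chain changed little, since a 1.1-fold higher number from compound 2 to compound 3 (0.05 log units; within the scatter); the two chain lengths behave alike here.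

Compound 4 `CCCCCCCCCNC(=O)[C@H]1OC(n2cnc3c(N)ncnc32)[C@H](O)[C@@H]1O` is compound 1 with nonyl in place of hydrogen on an amide-type nitrogen. The two relevant steps from compound 1 were both modest drops of about the same size, and extending the chain further brought nothing more. The same kind of change is therefore expected for compound 4, namely a 2.9-fold lower number from compound 1 to compound 4 (0.46 log units; beyond the scatter). The estimate for compound 4 in this assay is 22 nM, with an expected range from 8 nM to 65 nM.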

Compound 4, inhibition constant: 31 nM
Estimate against measurement, compound 4: 1.4-fold (0.15 log units) below, within the range that was stated.
By their numbers in this assay, from the lowest: compounds 2, 3 and 4 (each within the scatter of the next); then compound 1.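

Nonyl on the amide-type nitrogen still gives a lower number than the bare amide hydrogen in this assay (a 2.1-fold lower number from compound 1 to compound 4 (0.31 log units; beyond the scatter)), so a chain of this length keeps a modest part of the effect seen with the shorter chains. Butyl, hexyl and nonyl cannot be told apart (a 1.6-fold higher number from compound 3 to compound 4 (0.21 log units; within the scatter); a 1.8-fold higher number from compound 2 to compound 4 (0.26 log units; within the scatter)), which means these three compounds show no trend with chain length beyond the scatter. Nothing available explains why the three chains behave alike.

As far as these compounds go, whether a chain shorter than butyl, such as methyl or ethyl, already gives the same lowering stays open, as does the effect of a chain longer than nonyl. These compounds also do not show how a phenyl ring, or a chain ending in an amine or a carboxylic acid, would behave on this nitrogen.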